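Replacing the Aryl Ether with a Phenylsulfonyl Group

The source may report more compounds than this note shows. Statements on the series, on what has been measured and on what is new or still open speak of the compounds shown alone.

Three compounds sharing the core of compound 1 `CCc1ccc(OCCCN2CCC(C(c3ccc(F)cc3)c3ccc(F)cc3)CC2)c(OC)c1` have been measured in a functional assay (aorta) with Oryctolagus cuniculus as the target; on this read-out higher numbers stand for weaker binding and lower numbers for tighter binding. Compound 1 gives 2.51 nM. Compound 2 `COc1cc(C(=O)O)ccc1OCCCN1CCC(C(c2ccc(F)cc2)c2ccc(F)cc2)CC1` gives 79.4 nM, and compound 3 `CC(=O)Nc1ccc(OCCCN2CCC(C(c3ccc(F)cc3)c3ccc(F)cc3)CC2)cc1` gives 12.6 nM. Compound 3 thus stands second highest of the three numbers. The nearest other number is that of compound 1, the furthest that of compound 2. Among the measured compounds shown here, the steps to it were a 5.0-fold higher number from compound 1 to compound 3 (0.70 log units; beyond the scatter) and a 6.3-fold lower number from compound 2 to compound 3 (0.80 log units; beyond the scatter), both modest, whereas the single substituent change gave a 32-fold higher number from compound 1 to compound 2 (1.50 log units; beyond the scatter), a large step.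

Compound 4 `O=S(=O)(CCCN1CCC(C(c2ccc(F)cc2)c2ccc(F)cc2)CC1)c1ccccc1` is not yet measured. Its difference from compound 3 is phenylsulfonyl in place of 4-acetamidophenoxy on a saturated chain carbon, three bonds along the chain from an amine nitrogen in a ring. For the measured compounds named here, the two modest steps that altered the aryl group on the oxygen bear most closely on this change, but neither removed the ether oxygen itself, so there is no direct precedent for a phenylsulfonyl group at this place. The variation seen so far suggests a modest step in this assay, with direction uncertain and some lean toward a higher number.

Compound 4 is therefore expected to give about 25 nM in this assay, within 5 nM to 125 nM, which is an expected step of a 2.0-fold higher number from compound 3 to compound 4 (0.30 log units; within the scatter).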

Compound 4, dissociation constant: 20 nM
Beside the measured number, compound 4's estimate is 1.3-fold (0.10 log units) above it; measured number inside the range.
By their numbers in this assay, from the lowest: compound 1; then compounds 3 and 4 (each within the scatter of the next); then compound 2.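

In this assay, the link on a saturated chain carbon, three bonds along the chain from an amine nitrogen in a ring, need not be an ether oxygen: phenylsulfonyl replaces 4-acetamidophenoxy with a 1.6-fold higher number from compound 3 to compound 4 (0.20 log units; within the scatter) and so leaves the two compounds indistinguishable on this read-out. The same replacement, set against the other two ethers, gives a 4.0-fold lower number from compound 2 to compound 4 (0.60 log units; beyond the scatter) and an 8.0-fold higher number from compound 1 to compound 4 (0.90 log units; beyond the scatter) and so places compound 4 where compound 3 stood, with the 4-ethyl-2-methoxyphenoxy group of compound 1 still giving the lowest number. Nothing given here accounts for these numbers.

The compounds shown leave open how far the sulfonyl link and the unsubstituted phenyl ring each contribute, since this change altered both at once. Also open, going by these compounds, is whether an ethyl group, a methoxy group or a carboxylic acid on the phenylsulfonyl ring would reproduce the spread seen among the ethers, and whether a thioether link or a longer chain would hold the number at this place.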